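The source may hold more compounds than are shown below. What is called first, only, known or untested is meant among the compounds shown, and "the series" means these compounds.

Working notes on the series. In a functional assay on a cell-free system (plasma, Oryctolagus cuniculus) for inhibition, with stated times of 5 min, 1 min and 6 min (on this read-out higher numbers stand for weaker inhibition and lower numbers for stronger inhibition), compound 1 (`CCOC(=O)c1c(C)nc(-c2ccc(OCC(C)C)c(C#N)c2)n1O`) gives 16800 nM, compound 2 (`CCOC(=O)c1c(C)nc(-c2ccccc2C#N)n1OC`) gives 14900 nM and compound 3 (`CCOC(=O)c1c(C)nc(-c2cccc(C#N)c2)n1C`) gives 22100 nM. Compound 3 therefore stands level with the other two, as all three values lie within the scatter of each other.

Compound 4 (`CCOC(=O)c1c(C)nc(-c2cccc(C#N)c2)n1OCCCO`) departs from compound 3 at one place: 3-hydroxypropoxy in place of methyl on an aromatic nitrogen. Among the compounds with values here, no measured pair differs at a single place, so no measured step isolates this change. Within the data shown here, the only guide is indirect: with a different group on that nitrogen, and other differences as well, compound 1 reads 16800 nM and compound 2 reads 14900 nM.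

In this assay, no change beyond the scatter is therefore expected, and any direction is tentative. The expected step is a 1.4-fold lower number from compound 3 to compound 4 (0.14 log units; within the scatter), which is estimated to stay within the scatter. For compound 4 the estimated value is 16000 nM, with an expected range of 6000 nM to 40000 nM.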

Compound 4, half-maximal inhibitory concentration: 11400 nM
Compound 4: middle estimate off by 1.4-fold (0.15 log units), on the high side; the range from low to high includes it.
By their numbers in this assay, from the lowest: compounds 4, 2, 1 and 3 (each within the scatter of the next).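

Within the data shown here, this is the first step that isolates the group on the aromatic nitrogen: in this assay, 3-hydroxypropoxy in place of methyl gives a 1.9-fold lower number from compound 3 to compound 4 (0.29 log units; within the scatter). The entering group has 5 heavy atoms against 1 for methyl and adds 1 hydrogen-bond donor and 2 hydrogen-bond acceptors, yet the read-out stays within the scatter, so this position tolerates the exchange in this assay. No available evidence bears on the size of this step.

From the compounds shown here alone, whether the hydroxyl end of the chain contributes at all remains open, and a plain propoxy group on the same nitrogen would address that. Also open, going by these compounds, is whether a longer chain, an amine or a carboxylic acid there would move the number beyond the scatter in either direction.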